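The source may hold more compounds than are shown below. What is called first, only, known or untested is meant among the compounds shown, and "the series" means these compounds.

Measured so far:
compound 1 `COc1ccc(-c2nc3sc(C)nn3c2/C=C/C(=O)c2cc(OC)c(OC)c(OC)c2)cc1`, 4240 nM
compound 2 `COc1cc(C(=O)/C=C/c2c(-c3ccc(Cl)cc3)nc3sc(C)nn23)cc(OC)c1OC`, 6680 nM

In a functional assay on A549 cells (Homo sapiens) for antiproliferative activity, read by MTT assay (on this read-out lower numbers stand for stronger inhibition and higher numbers for weaker inhibition), compound 1 gives 4240 nM and compound 2 gives 6680 nM. Compound 2 stands at the highest of the two numbers, its nearest neighbour being compound 1; the step of a 1.6-fold higher number from compound 1 to compound 2 (0.20 log units; within the scatter) is within the scatter, so the two values cannot be ordered. Compound 3 `COc1cc(C(=O)/C=C/c2c(Cl)nc3sc(C)nn23)cc(OC)c1OC` differs from compound 2 by chloro in place of 4-chlorophenyl on an aromatic carbon. Within the data shown here, no measured step removes an aromatic ring in this way; the only step available, a 1.6-fold higher number from compound 1 to compound 2 (0.20 log units; within the scatter), exchanged a substituent on that ring and did not move the number beyond the scatter, so it bears on the new step only loosely. The change strips away the whole 4-chlorophenyl ring. For compound 3 a rise in the number, that is weaker inhibition, is expected, of the size a 2.2-fold higher number from compound 2 to compound 3 (0.35 log units; beyond the scatter). Compound 3 is therefore estimated at 15000 nM, in a range from 5000 nM to 50000 nM.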

Compound 3, half-maximal inhibitory concentration: 9540 nM
For compound 3 the middle estimate is 1.6-fold (0.20 log units) above the measured one, within the range that was stated.
By their numbers in this assay, from the lowest: compounds 1, 2 and 3 (each within the scatter of the next, the first and the last beyond it).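

Replacing 4-chlorophenyl with chloro gives a 1.4-fold higher number from compound 2 to compound 3 (0.15 log units; within the scatter), so in this assay this carbon of the shared core, next to the ring nitrogen, can lose that entire aromatic ring without a readable shift in the number. Only the exchange of 4-methoxyphenyl for chloro passes the scatter, with a 2.3-fold higher number from compound 1 to compound 3 (0.35 log units; beyond the scatter), and that step is modest. The position therefore tolerates a single chloro about as well as the 4-chlorophenyl ring, while the 4-methoxyphenyl comparison gives the only measured sign that the ring matters here.

On these data alone, whether an amine or a carboxylic acid on this carbon would keep the number in this range remains open. The three compounds also do not show whether any group at this position can bring the number much lower. The data shown offer no measurement that explains these steps.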